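The compounds below may be only part of what the source reports. "The series", "measured", "known", "first", "only" and "open" are said of these compounds alone.

Measured so far in a functional assay on CHO cells with adenosine receptor A1 (Homo sapiens) as the target, read by cAMP accumulation and immunoassay, with a stated time of 6 min, tested at 0.01 uM; on this read-out higher numbers stand for a weaker effect at the one concentration tested and lower numbers for a stronger effect:

compound 1 `Nc1scc(CN2CCN(c3cccc(Cl)c3Cl)CC2)c1C(=O)c1ccc(Cl)cc1`: 1%
compound 2 `Nc1scc(CN2CCN(c3ccc(Cl)c(C(F)(F)F)c3)CC2)c1C(=O)c1ccc(Cl)cc1`: -2.5%
compound 3 `Nc1scc(CN2CCN(c3cc(F)ccc3F)CC2)c1C(=O)c1ccc(Cl)cc1`: 3.1%

Compound 3 holds the largest of the three numbers in this assay, but its steps from compound 1 a number 2.1 percentage points higher from compound 1 to compound 3 (within the scatter) and from compound 2 a number 5.6 percentage points higher from compound 2 to compound 3 (within the scatter) both lie within the scatter, so the three compounds are not separated on this read-out.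

Compound 4 `Nc1scc(CN2CCN(c3ccc(Cl)c(Cl)c3)CC2)c1C(=O)c1ccc(Cl)cc1` differs from compound 3 in one place: 3,4-dichlorophenyl in place of 2,5-difluorophenyl on an amine nitrogen in a ring. Every measured step in the series is a swap of the aryl group on the ring nitrogen, and each of them, a number 3.5 percentage points lower from compound 1 to compound 2 (within the scatter), a number 2.1 percentage points higher from compound 1 to compound 3 (within the scatter) and a number 5.6 percentage points higher from compound 2 to compound 3 (within the scatter), stayed within the scatter. For compound 4 the same is therefore expected, a step of a number 2.1 percentage points lower from compound 3 to compound 4 (within the scatter) with no change beyond the scatter. The estimate for compound 4 is 1%, within a range of -8% to 10%.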

Compound 4, a percentage reported as activity, at one concentration (the size of the read-out at that concentration, not a potency): -1.2%
Compound 4: middle estimate off by 2.2 percentage points, on the high side; the range from low to high includes it.
By their numbers in this assay, from the lowest: compounds 2, 4, 1 and 3 (each within the scatter of the next).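

Placing the two dichlorophenyl patterns side by side on the ring nitrogen, 3,4-dichlorophenyl in place of 2,3-dichlorophenyl gives a number 2.2 percentage points lower from compound 1 to compound 4 (within the scatter). The single-substituent swap on the aryl ring, chloro in place of trifluoromethyl, gives a number 1.3 percentage points higher from compound 2 to compound 4 (within the scatter), and 3,4-dichlorophenyl in place of 2,5-difluorophenyl gives a number 4.3 percentage points lower from compound 3 to compound 4 (within the scatter), so this assay separates neither change. No available evidence accounts for these small steps. Still open, from the compounds shown here alone, is whether an aryl group carrying an amine or a carboxylic acid, or a longer alkyl chain in place of the aryl group, would produce a step beyond the scatter.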